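Methyl on the benzyl group of compound 1

The source may report more compounds than this note shows. Statements on the series, on what has been measured and on what is new or still open speak of the compounds shown alone.

In a functional assay (QGY7701 cells, Homo sapiens) for inhibition, read by MTT assay, with a stated time of 48 h (a higher number here means a weaker inhibitor, a lower number a stronger inhibitor), compound 1 `O=C(/C=C/c1coc2cc(O)ccc2c1=O)NCc1ccccc1` gives 63000 nM. Compound 3 `COc1ccc2c(=O)c(/C=C/C(=O)NCc3ccccc3F)coc2c1` gives 34000 nM, and these two numbers lie within the scatter of each other. Compound 2 `COc1ccc2c(=O)c(/C=C/C(=O)NCc3ccccc3)coc2c1` reads > 100000 nM, which is a limit of the assay and not a number. For the measured compounds named here, the series therefore holds only two true numbers, and they are not separated.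

Compound 4 `Cc1ccc(CNC(=O)/C=C/c2coc3cc(O)ccc3c2=O)cc1` keeps the core of compound 1 and turns benzyl into 4-methylbenzyl: methyl in place of hydrogen on an aromatic carbon. This is methyl in place of hydrogen on an aromatic carbon, para to a large group.

Going by the values given here, two measured steps bear on this, both loosely. Methyl in place of hydrogen on an oxygen on an aromatic ring gives an at least 1.5-fold higher number from compound 1 to compound 2 (0.20 log units; that floor lies within the scatter), but that change lies on the core, not the benzyl group. Closer is fluoro in place of hydrogen on an aromatic carbon of the benzyl group, where an at least 2.9-fold lower number from compound 2 to compound 3 (0.46 log units; beyond the scatter) supports a slight expected lean towards a lower number for compound 4. That step starts from a limit, however, and brings in a different group on a different core.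

No step beyond the scatter is expected in this assay. The estimated step is a 1.5-fold lower number from compound 1 to compound 4 (0.18 log units; within the scatter). For compound 4 the expected value is 42000 nM, with an estimated range of 17000 nM to 100000 nM.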

Compound 4, half-maximal inhibitory concentration: 24900 nM
For compound 4 the middle estimate is 1.7-fold (0.23 log units) above the measured one; the range from low to high includes it.
By their numbers in this assay, from the lowest: compounds 4, 3 and 1 (each within the scatter of the next, the first and the last beyond it). At a limit, above all of these: compound 2.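

Working notes on the series. In this assay, for the compounds shown here, methyl in place of hydrogen on an aromatic carbon, para to a large group, gives a 2.5-fold lower number from compound 1 to compound 4 (0.40 log units; beyond the scatter), the first change on the benzyl group that can be read between two true numbers. Compound 2 stands at a limit and not at a number, so the earlier change on the benzyl group has no true starting value: the limit of > 100000 nM in this assay, at which 1 of the 4 values shown sits. The new step shows that, on the core of compound 1, this position takes a methyl with a modest move towards a lower number, although this rests on a single pair and says nothing yet about a trend at this position.

As far as these compounds go, whether a larger group at this place, such as an ethyl or a longer chain, or a different kind of group, such as an amine or a carboxylic acid, moves the number further in the same direction remains open. Also open, from the compounds shown here alone, is whether the 4-methylbenzyl group gives the same step on the core of compound 2, where the oxygen carries a methyl.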